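The source may hold more compounds than are shown below. What is called first, only, known or untested is meant among the compounds shown, and "the series" means these compounds.

Measured in a functional assay on P388 cells (Mus musculus); a higher number here means that more compound is needed for the effect, a lower number that less compound is needed:
- compound 1 `Nc1ncn(C[C@@H]2CO[C@H](CO)O2)c(=O)n1`: 90000 nM
- compound 2 `Nc1ncn(C[C@H]2CO[C@H](CO)O2)c(=O)n1`: 65000 nM
- compound 3 `Cc1nn(C[C@H]2CO[C@H](CO)O2)c(=O)[nH]c1=O`: > 100000 nM

The value for compound 3 is a limit of the assay, not a number.

Compound 2, at 65000 nM, has the lowest number of the two true values in this assay, but it cannot be separated from compound 1, at 90000 nM. The step between them is a 1.4-fold lower number from compound 1 to compound 2 (0.14 log units; within the scatter).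

The next compound to consider is compound 4 `Nc1ncn(C[C@H]2CO[C@@H](CO)O2)c(=O)n1`. Compared with compound 2, the change is the two compounds have the same atoms and bonds and differ only in configuration as drawn: 1 of 2 stereo elements differ; a stereocentre at a saturated ring carbon is drawn S in compound 2 and R in compound 4. No atom is added or removed, so only the three-dimensional arrangement at that one carbon is different.

Among the compounds with values here, only one measured step bears on this change, the one from compound 1 to compound 2, which also reverses a single stereocentre. It stayed within the scatter, as a 1.4-fold lower number from compound 1 to compound 2 (0.14 log units; within the scatter) shows. However, it concerns a different stereocentre, so it is a guide and not proof.

On that single precedent, the expected change is small: a 1.1-fold higher number from compound 2 to compound 4 (0.03 log units; within the scatter), with no clear direction beyond the scatter. Compound 4 could also end at the limit of > 100000 nM in this assay, at which 1 of the 3 values shown sits. For compound 4, the estimated value is 70000 nM, with an expected range from 30000 nM to 130000 nM.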

Compound 4, half-maximal effective concentration: 70000 nM
Compound 4: middle estimate and measured number agree at the digits printed; measured number inside the range.
By their numbers in this assay, from the lowest: compounds 2, 4 and 1 (each within the scatter of the next). At a limit, above all of these: compound 3.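

In this assay, inverting the second stereocentre also leaves the number within the scatter, with a 1.1-fold higher number from compound 2 to compound 4 (0.03 log units; within the scatter), so each of the two stereocentres has now been inverted on its own without a step that stands out from the scatter: the fact that compounds 2 and 4 differ only in the configuration as drawn. Inverting both at once, which gives the mirror image, likewise stays within the scatter, with a 1.3-fold lower number from compound 1 to compound 4 (0.11 log units; within the scatter): the fact that compounds 1 and 4 differ only in the configuration as drawn. Among compounds 1, 2 and 4, then, this assay gives no sign that the configuration at either carbon matters, a stronger reading than the single earlier step could support, though it holds only for these three compounds.

Still open, from the compounds shown here alone, is whether the mirror image of compound 2 would fall in the same range, and whether configuration would start to matter in a compound that needs far less material for the effect. The compounds shown also say nothing about how this series would respond if the hydroxyl group gave way to an amine, a carboxylic acid or a longer chain.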